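Methyl in Place of Methoxy: Expecting Compound 4

This account rests on a few compounds, and the source may have more. Where it says the series, first, only, none or still open, it means among the compounds named here.

Compound 1, `COc1cccc(N2CCN(C(=O)C(C)N3C(=O)CCC3=O)CC2)c1`, in a functional assay on the whole organism (strain Swiss) with Mus musculus as the target, in the maximal electroshock model, with a stated time of 1 h, at a dose of 100 mg/kg by the intraperitoneal route (a higher number here means a stronger effect of the compound at the dose given, a lower number a weaker effect), gives 0%.
Compound 2, `CCC(C(=O)N1CCN(c2cccc(C(F)(F)F)c2)CC1)N1C(=O)CCC1=O`, in this assay gives 0%.
Compound 3, `CCC(C(=O)N1CCN(c2cccc(Cl)c2)CC1)N1C(=O)CCC1=O`, in this assay gives 0%.

All three measured compounds share the same core and differ only in the group on the aromatic ring and in the short chain next to the carbonyl. None of them shows any effect in this assay at the dose tested, and compound 1 stands level with compounds 2 and 3 at the digits recorded, nearest to compound 2 and furthest from compound 3, both within the scatter.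

Compound 4, `Cc1cccc(N2CCN(C(=O)C(C)N3C(=O)CCC3=O)CC2)c1`, is the next compound to be measured. It differs from compound 1 by methyl in place of methoxy on an aromatic carbon.

For the measured compounds named here, only one measured step exists, no change at the digits printed from compound 2 to compound 3 (within the scatter), and it concerns a different exchange of groups, so it does not bear directly on a methyl replacing a methoxy. It does show that swapping one group on the aromatic ring for another left the read-out unchanged. With the whole set sitting at the same value, no step beyond the scatter is expected from compound 1 to compound 4, that is no change at the digits printed from compound 1 to compound 4 (within the scatter). Compound 4 is therefore estimated to give 0% in this assay, with a range from 0% to 10%.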

Compound 4, a percentage reported as activity, at one dose (the size of the read-out at that dose, not a potency): 0%
The estimate for compound 4 equals the measured number at the digits printed; low and high end bracket the measured number.
By their numbers in this assay, from the lowest: compounds 1, 2, 3 and 4 (each within the scatter of the next).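

In this assay, the reading reported as no change at the digits printed from compound 1 to compound 4 (within the scatter) comes with the 3-methoxyphenyl group giving way to 3-methylphenyl, a change that takes away an oxygen atom and the one hydrogen-bond acceptor that methoxy carries. For the compounds shown here, the one earlier step was an exchange of chloro for trifluoromethyl, so this is the first step in the set where a hydrogen-bond acceptor leaves this ring, and here the acceptor can go without any shift in the read-out at the dose given. No measurement offers an explanation for this unchanged reading.

All the compounds shown sit at one and the same reading, so this position has yet to produce any difference in effect, and the set cannot say whether the group on the ring matters at all in this test or whether the effect is simply absent whatever stands there. Going by these compounds, whether an amine, a hydroxyl group or a carboxylic acid on this aromatic carbon would give a reading different from methyl and methoxy remains open.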